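The source may report more compounds than this note shows. Statements on the series, on what has been measured and on what is new or still open speak of the compounds shown alone.

Series in a functional assay on T47D cells (Homo sapiens) for inhibition, read by sulforhodamine B assay, with a stated time of 48 h (a higher number here means a weaker inhibitor of growth, a lower number a stronger inhibitor of growth), measured so far:

Compound 1 `O=C(/C(=C/c1ccc(Cl)cc1)CCl)c1ccccc1` gives 17000 nM.
Compound 2 `O=C(/C(=C/c1ccc(Cl)cc1Cl)CCl)c1ccccc1` gives 6300 nM.
Compound 3 `CC(=O)OC/C(=C\c1ccccc1Br)C(=O)c1ccccc1` gives 17000 nM.

Compound 2 stands lowest of the three numbers in this assay; both other compounds sit higher by steps beyond the scatter. Among the measured compounds shown here, the one single-point step measured is a 2.7-fold lower number from compound 1 to compound 2 (0.43 log units; beyond the scatter), a modest gain from the added chloro on the aromatic carbon.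

The next compound, compound 4 `CC(=O)OC/C(=C\c1ccc(Cl)cc1Cl)C(=O)c1ccccc1`, keeps the dichlorinated aryl ring of compound 2 and carries the change (acetoxy in place of chloro on a saturated chain carbon bound to a double-bonded chain carbon), i.e. chloromethyl to acetoxymethyl. For the measured compounds named here, no measured step covers this exact change. Compound 1 and compound 3 differ from each other in this group and also in the aryl substitution, so their equal numbers cannot be attributed to the chloromethyl-to-acetoxymethyl swap alone. Going by the values given here, with no step bearing on it, the expectation for compound 4 is no change beyond the scatter, a 1.3-fold higher number from compound 2 to compound 4 (0.10 log units; within the scatter). Compound 4 is therefore estimated at 8000 nM, with a range from 2500 nM to 25000 nM.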

Compound 4, concentration for 50% growth inhibition: 9500 nM
Beside the measured number, compound 4's estimate is 1.2-fold (0.07 log units) below it; low and high end bracket the measured number.
By their numbers in this assay, from the lowest: compounds 2, 4, 1 and 3 (each within the scatter of the next, the first and the last beyond it).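

In this assay the chloromethyl to acetoxymethyl change now has its first single-point reading, a 1.5-fold higher number from compound 2 to compound 4 (0.18 log units; within the scatter) on the dichlorinated aryl ring. On this ring, the saturated chain carbon bound to a double-bonded chain carbon thus takes acetoxy, with 4 heavy atoms and 2 hydrogen-bond acceptors, in place of chloro with no shift beyond the scatter. No supporting data bear on why the two groups read alike here.

Open, from the compounds shown here alone, is whether the same change reads alike on the aryl ring of compound 1, which carries one chloro, since this single pair covers only the dichlorinated ring. Also open, going by these compounds, is whether an amine or a free hydroxy at this chain carbon would stay within the scatter of compound 2 in this assay as acetoxy does.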